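This account rests on a few compounds, and the source may have more. Where it says the series, first, only, none or still open, it means among the compounds named here.

Of the compounds shown here, three have been measured in a functional assay on HT-29 cells (Homo sapiens) for antiproliferative activity, read by sulforhodamine B assay, with a stated time of 48 h; on this read-out lower numbers stand for stronger inhibition and higher numbers for weaker inhibition. Compound 1 `CC(C)c1ccccc1OS(=O)(=O)c1cccc(NC(=O)C(C)(C)C)c1` gives 19000 nM in this assay. Compound 2 `CC(=O)Nc1ccc(S(=O)(=O)Oc2ccccc2C(C)C)cc1` gives 23000 nM, and compound 3 `CC(=O)Nc1ccc(S(=O)(=O)Oc2ccccc2I)cc1` gives 23000 nM. Compound 3 thus stands level with compound 2 at the digits shown, the two together the highest of the three numbers, while compound 1 differs from compound 3 only within the scatter. Among the compounds with values here, the single step between compounds that differ in one place, no change at the digits printed from compound 2 to compound 3 (within the scatter), moved nothing. Compound 4 `CC(C)(C)C(=O)Nc1ccc(S(=O)(=O)Oc2ccccc2I)cc1` is reached from compound 3 by tert-butyl in place of methyl on a carbonyl carbon. Within the data shown here, no measured step isolates this change: compound 1 also carries the tert-butyl on its carbonyl carbon, but it differs from compound 2 in two places, and the values of compound 1 and compound 2 lie within the scatter of each other. With nothing in the data pulling either way, the step of a 1.0-fold lower number from compound 3 to compound 4 (0.02 log units; within the scatter) is expected to lie within the scatter. Compound 4 is therefore estimated at 22000 nM, in the range 11000 nM to 45000 nM.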

Compound 4, half-maximal inhibitory concentration: 9500 nM
Compound 4: middle estimate off by 2.3-fold (0.36 log units), on the high side; the measured number lies below the stated range.
By their numbers in this assay, from the lowest: compounds 4, 1, 2 and 3 (each within the scatter of the next, the first and the last beyond it).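

In this assay, within the data shown here, the group on the carbonyl carbon whose other neighbour is the amide-type nitrogen is the first place in this set where a single change moves the number beyond the scatter: tert-butyl in place of methyl gives a 2.4-fold lower number from compound 3 to compound 4 (0.38 log units; beyond the scatter), a modest step read only on the iodo compounds. Among these compounds, the one earlier step, iodo in place of isopropyl, gave no change at the digits printed from compound 2 to compound 3 (within the scatter), so it showed no such movement. Nothing given here bears on what lies behind the drop in the number.

Open, on these data alone, is how an ethyl or isopropyl on that carbonyl carbon would read against methyl and tert-butyl, and how a chain ending in an amine or a carboxylic acid would read there. Also open, as far as these compounds go, is whether the same change would give a step of this size with isopropyl in place of iodo.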